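A few compounds are considered here, and "the series" means these few. Any claim that something is new, unique, unknown or untested is made for them only; others in the source may bear on it.

Measured compounds in this series:

- compound 1: `CC1CCN(c2nc(C(F)(F)F)ccc2CNC(=O)C(C)c2ccc(NS(C)(=O)=O)c(Cl)c2)CC1` — in an assay on cells for antagonist activity at transient receptor potential cation channel subfamily V member 1 (Homo sapiens), read by FLIPR and calcium flux, with a stated time of 15 min (on this read-out higher numbers stand for weaker inhibition and lower numbers for stronger inhibition), compound 1 gives 2.3 nM
- compound 2: `CC1CCN(c2nc(C(F)(F)F)ccc2CNC(=O)C(C)c2cc(F)c(NS(C)(=O)=O)c(Br)c2)CC1` — in this assay compound 2 gives 0.7 nM

Of the two numbers, compound 2 has the lower one; the gap to compound 1 is beyond the scatter, so compound 2 stands as the stronger inhibitor of the pair. Within the data shown here, no single-change step between the two has been worked out, as compound 1 and compound 2 differ in more than one place.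

Compound 3 is `COc1cc(C(C)C(=O)NCc2ccc(C(F)(F)F)nc2N2CCC(C)CC2)cc(F)c1NS(C)(=O)=O` and has not yet been measured in this assay. It differs from compound 2 in one place: methoxy in place of bromo on an aromatic carbon. Nothing measured here isolates the effect of a methoxy group at that place. The expectation, resting only on compound 2 giving 0.7 nM and on the change itself, is a moderate loss of potency, with the step from compound 2 to compound 3 estimated at a 2.9-fold higher number from compound 2 to compound 3 (0.46 log units; beyond the scatter). For compound 3 the estimate is 2 nM, within a range of 0.5 nM to 8 nM.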

Compound 3, inhibition constant: 0.3 nM
Compound 3: middle estimate off by 6.7-fold (0.82 log units), on the high side; the measured number lies below the stated range.
By their numbers in this assay, from the lowest: compound 3; then compound 2; then compound 1.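

At this place, ortho to a methanesulfonamido group and meta to a fluoro group, methoxy in place of bromo gives in this assay a 2.3-fold lower number from compound 2 to compound 3 (0.37 log units; beyond the scatter), a modest step beyond the scatter. Among these compounds, the position therefore accepts a group of two heavy atoms with one hydrogen-bond acceptor in place of a single bromine atom, with no loss of potency, which the earlier compounds could not show since both carry a halogen here. No measurement at hand bears on the reason for this step.

From the compounds shown here alone, whether the gain depends on the oxygen or on the methyl attached to it stays open; a hydroxyl, an ethoxy group or an amine at this place would separate these. Also open, going by these compounds, is whether the step carries over without the fluoro group, which compound 2 and compound 3 share.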